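The source may hold more compounds than are shown below. What is called first, only, known or untested is meant among the compounds shown, and "the series" means these compounds.

For the measured compounds named here, compound 2 `CC1=CC[C@H](C(C)(C)NC(=S)N/N=C/c2ccc(Cl)cc2)CC1` gives 50 nM in a functional assay on PC-3 cells (Homo sapiens) for inhibition, read by sulforhodamine B assay, with a stated time of 48 h (on this read-out higher numbers stand for weaker inhibition of growth and lower numbers for stronger inhibition of growth), the only plain number reported there. Compound 1 `CC1=CC[C@H](C(C)(C)NC(=S)N/N=C/c2ccc(F)cc2)CC1` is reported in this assay only as a limit, < 40 nM. Going by the values given here, the one measured step, an at least 1.2-fold higher number from compound 1 to compound 2 (0.09 log units; that floor lies within the scatter), concerns a halogen swap; it bears only loosely on the change to compound 3 `CC1=CC[C@H](C(C)(C)NC(=S)N/N=C/c2cccs2)CC1`, which replaces the whole ring: thiophen-2-yl in place of 4-chlorophenyl on a carbon with a double bond to nitrogen. Among the compounds with values here, no measured step exchanges one aromatic ring for another. A step within the scatter is therefore expected, a 1.2-fold higher number from compound 2 to compound 3 (0.08 log units; within the scatter). Compound 3 is estimated at 60 nM, between 25 nM and 150 nM.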

Compound 3, concentration for 50% growth inhibition: 17800 nM
The estimate for compound 3 lay 300-fold (2.47 log units) below the measured number; measured number above the stated range.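

In this assay, the ring on the carbon with a double bond to nitrogen proves far from interchangeable: thiophen-2-yl in place of 4-chlorophenyl gives a 360-fold higher number from compound 2 to compound 3 (2.55 log units; beyond the scatter). The same exchange against 4-fluorophenyl gives an at least 440-fold higher number from compound 1 to compound 3 (2.64 log units; beyond the scatter), so the loss appears with either halogen-bearing ring, a change the halogen swap alone gave no sign of. That second step is only a floor, as compound 1 stands as a limit: the limit of < 40 nM in this assay, at which 1 of the 3 values shown sits.

The compounds shown leave open whether the loss follows the five-membered ring, its sulfur or the absent halogen. An unsubstituted phenyl, a furan-2-yl or a 5-chlorothiophen-2-yl could separate these.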